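Ethoxy for Fluoro on the Fused Ring

The source may hold more compounds than are shown below. What is called first, only, known or untested is meant among the compounds shown, and "the series" means these compounds.

Of the compounds shown here, three that share one core have been measured in a functional assay on Hep 3B2 cells (Homo sapiens) for antiproliferative activity, read by MTT assay, with a stated time of 24 h, tested at 3.7 ug/mL; a higher number here means a stronger effect of the compound at the concentration tested, a lower number a weaker effect. Compound 1 `Cc1ccc2nc(C(=O)Nc3c(F)cc(-c4cccc(F)c4)cc3F)c(C)c(O)c2c1` gives 19.2%. Compound 2 `CCc1ccc2nc(C(=O)Nc3c(F)cc(-c4cccc(F)c4)cc3F)c(C)c(O)c2c1` carries an ethyl where compound 1 carries a methyl; in this assay compound 2 gives 31.2%. Compound 3 `Cc1c(C(=O)Nc2c(F)cc(-c3cccc(F)c3)cc2F)nc2ccc(F)cc2c1O` gives 22.3%. Among these three numbers compound 3 stands second highest, its nearest neighbour being compound 1 and its furthest compound 2, yet both gaps lie within the scatter, so the three compounds can hardly be told apart on these numbers.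

Compound 4 `CCOc1ccc2nc(C(=O)Nc3c(F)cc(-c4cccc(F)c4)cc3F)c(C)c(O)c2c1` has not yet been measured. It differs from compound 3 in one place: ethoxy in place of fluoro on an aromatic carbon.

For the measured compounds named here, two measured steps touch the same position. The step of a number 3.1 percentage points higher from compound 1 to compound 3 (within the scatter) stays within the scatter, and so does the step of a number 8.9 percentage points lower from compound 2 to compound 3 (within the scatter). Going by the values given here, the only step beyond the scatter, a number 12 percentage points higher from compound 1 to compound 2 (beyond the scatter), concerns a different position on the core. Because the step of a number 8.9 percentage points lower from compound 2 to compound 3 (within the scatter) stayed within the scatter although ethyl and fluoro are quite different groups, compound 4 is expected to change little, with the step of a number 4.7 percentage points higher from compound 3 to compound 4 (within the scatter) probably within the scatter. Compound 4 is therefore estimated at 27% in this assay, with a range from 14% to 42%.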

Compound 4, a percentage reported as inhibition, at one concentration (the size of the read-out at that concentration, not a potency): 1.56%
Compound 4: middle estimate off by 25.4 percentage points, on the high side, and the stated range ends above it.
By their numbers in this assay, from the lowest: compound 4; then compounds 1, 3 and 2 (each within the scatter of the next, the first and the last beyond it).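

In this assay, for the compounds shown here, the group on the fused ring turns out to matter in a downward direction as well: ethoxy in place of fluoro gives a number 20.7 percentage points lower from compound 3 to compound 4 (beyond the scatter) and is the first fall beyond the scatter at this position. Ethoxy in place of ethyl gives a number 29.6 percentage points lower from compound 2 to compound 4 (beyond the scatter) even though ethoxy differs from ethyl by the oxygen atom that joins it to the ring, so the gain on going from methyl to ethyl does not carry over to ethoxy. Ethoxy in place of methyl gives a number 17.6 percentage points lower from compound 1 to compound 4 (beyond the scatter) as well, which sets compound 4 apart from all three other compounds as the lowest of the series, but no measurement at hand explains why the number falls.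

On these data alone, what remains open is whether the fall follows the oxygen atom or the length of the group, a question that methoxy and propyl at this same position could help to separate. As far as these compounds go, it is also open whether a hydroxy group or an amine there would behave like ethoxy or like the groups that keep the number higher, and a single-concentration read-out says nothing about potency.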